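Side-chain amines on a fluoroindole myeloperoxidase series

The source may report more compounds than this note shows. Statements on the series, on what has been measured and on what is new or still open speak of the compounds shown alone.

Measured compounds:
compound 1 `N#CCCCc1c[nH]c2ccc(F)cc12` gives 63 nM
compound 2 `NCCCCc1c[nH]c2c(F)cccc12` gives 6 nM
compound 3 `NC(=O)CCc1c[nH]c2c(F)cccc12` gives 271 nM

In an assay on isolated protein (urine) for inhibition of Myeloperoxidase (Homo sapiens), with a stated time of 5 min (a higher number here means a weaker inhibitor, a lower number a stronger inhibitor), compound 1 stands second highest of the three numbers: compound 3 sits above it, and compound 2 sits well below it. Compound 4 `NCC(N)CCc1c[nH]c2ccc(F)cc12` has not yet been measured; it differs from compound 1 by 1,2-diaminoethyl in place of cyanomethyl on a saturated chain carbon, two bonds along the chain from an aromatic carbon. Among the measured compounds shown here, no measured pair captures exactly this exchange. For the measured compounds named here, the one measured step that bears on it is the exchange of a basic amine for an amide, a 45-fold higher number from compound 2 to compound 3 (1.65 log units; beyond the scatter), which shows that losing the amine end of the chain weakens inhibition considerably. Going by the values given here, compounds 1 and 2 differ in two places at once, so they give no clean step, but their values show the amine-bearing compound 2 far lower than the nitrile-bearing compound 1. Compound 4 carries two amines where compound 1 carries a nitrile, so a drop in number toward the level of compound 2 is expected, estimated as a 6.3-fold lower number from compound 1 to compound 4 (0.80 log units; beyond the scatter). The estimate for compound 4 is therefore 10 nM, expected to fall between 3 nM and 40 nM.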

Compound 4, half-maximal inhibitory concentration: 60 nM
Beside the measured number, compound 4's estimate is 6.0-fold (0.78 log units) below it; the measured number lies above the stated range.
By their numbers in this assay, from the lowest: compound 2; then compounds 4 and 1 (each within the scatter of the next); then compound 3.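

In this assay, 1,2-diaminoethyl in place of cyanomethyl on a saturated chain carbon, two bonds along the chain from an aromatic carbon, gives a 1.1-fold lower number from compound 1 to compound 4 (0.02 log units; within the scatter), so the two groups cannot be told apart here on the core of compound 1. Among the compounds shown here, the earlier compounds did not show this: their only clean step, a 45-fold higher number from compound 2 to compound 3 (1.65 log units; beyond the scatter), exchanged different groups on a different core and was large. On this evidence, that large step does not carry over to this exchange, and a side chain with amines offers no measurable gain over the nitrile on this core. Nothing given here accounts for the result.

As far as these compounds go, it remains open whether a single amine, as 2-aminoethyl in place of cyanomethyl, would read differently from 1,2-diaminoethyl on this core, and how a carboxylic acid would compare in the same place. From the compounds shown here alone, it is also open whether the same exchange of cyanomethyl for 1,2-diaminoethyl would give a similar result on the core of compound 2.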